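Swapping Trifluoromethyl for Fluoro in Compound 2

A few compounds are considered here, and "the series" means these few. Any claim that something is new, unique, unknown or untested is made for them only; others in the source may bear on it.

Of the compounds shown here, two have been measured in a functional assay on PC-3 cells (Homo sapiens) for cytotoxicity, read by MTT assay, with a stated time of 72 h; on this read-out lower numbers stand for stronger inhibition and higher numbers for weaker inhibition. Compound 1 `CC1=C(/C=C/C(=O)/C=C/c2ccccc2F)C(C)(C)CCC1` gives 22100 nM in this assay. Compound 2 `CC1=C(/C=C/C(=O)/C=C/c2ccccc2C(F)(F)F)C(C)(C)CCC1O` gives 3700 nM, the lowest of the two numbers; compound 1 sits a clear gap above it, beyond the scatter. Compound 2 and compound 1 differ in two places at once, so their gap cannot be assigned to either change alone. Compound 3 `CC1=C(/C=C/C(=O)/C=C/c2ccccc2F)C(C)(C)CCC1O` is not yet measured. It differs from compound 2 in one place: fluoro in place of trifluoromethyl on an aromatic carbon. Among the measured compounds shown here, no step between measured compounds isolates this change, so the expectation rests on the whole set. Because compound 1 gives 22100 nM while carrying fluoro, and compound 2 gives 3700 nM while carrying trifluoromethyl, a modest weakening is expected, estimated as a 2.2-fold higher number from compound 2 to compound 3 (0.33 log units; beyond the scatter). Compound 3 is thus expected to give about 8000 nM in this assay, within a range of 2500 nM to 25000 nM.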

Compound 3, half-maximal inhibitory concentration: 10400 nM
For compound 3 the middle estimate is 1.3-fold (0.11 log units) below the measured one, within the range that was stated.
By their numbers in this assay, from the lowest: compound 2; then compound 3; then compound 1.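

In this assay the aromatic carbon can now be read on its own: with the hydroxy group held in place, fluoro in place of trifluoromethyl gives a 2.8-fold higher number from compound 2 to compound 3 (0.45 log units; beyond the scatter) on this position. Among the compounds shown here, the saturated ring carbon can also be read on its own for the first time: with fluoro held in place, hydroxy in place of hydrogen gives a 2.1-fold lower number from compound 1 to compound 3 (0.33 log units; beyond the scatter) and so both of the changes that were tangled earlier move the number beyond the scatter. Nothing at hand explains either step.

On these data alone, each step is known in one setting only, so it stays open whether the trifluoromethyl step would look the same on a core without the hydroxy group. As far as these compounds go, how a chloro, methoxy or nitrile group would fare on this aromatic carbon also remains open.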